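A few compounds are considered here, and "the series" means these few. Any claim that something is new, unique, unknown or untested is made for them only; others in the source may bear on it.

Measured compounds in a functional assay on the whole organism for antagonist activity, with Mus musculus as the target; a lower number here means that less compound is needed, a higher number that more compound is needed for the effect:

Compound 1, `COc1cc(N)c(Cl)cc1NC(=O)C1CCN(Cc2ccccc2Cl)CC1`, gives > 4 mg/kg, which is a limit of the assay and not a number.
Compound 2, `COc1cc(N)c(Cl)cc1NC(=O)C1CCN(CC2CCCC2)CC1`, gives > 10 mg/kg, again only a limit.
Compound 3, `CCCCCN1CCC(C(=O)Nc2cc(Cl)c(N)cc2OC)CC1`, gives > 10 mg/kg, again only a limit.

Compound 1 therefore stands nowhere definite in this assay: its own value is a limit, and the two further values shown are limits too, one at the limit of > 10 mg/kg in this assay, at which 2 of the 3 values shown sit, and one at the limit of > 4 mg/kg in this assay, at which 1 of the 3 values shown sits. The step that the two limits leave unreadable from compound 1 to compound 2 cannot be read in size, and neither can a step that the two limits leave unreadable from compound 1 to compound 3 or a step that the two limits leave unreadable from compound 2 to compound 3.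

Compound 4, `COc1cc(N)c(Cl)cc1NC(=O)C1CCN(Cc2ccccc2)CC1`, differs from compound 1 in one place: hydrogen in place of chloro on an aromatic carbon. None of the three measured steps touches that place; all three concern the group on the saturated chain carbon bound to the amine nitrogen in the ring, and all three are unreadable. Going by the values given here, no measured step therefore bears directly on this change, and no direction can be taken from the data.

With every value shown sitting at a limit, compound 4 is expected to sit near those limits as well, with an estimated step that the limit leaves unreadable from compound 1 to compound 4. Compound 4 is accordingly estimated at 10 mg/kg in this assay, within a range from 3 mg/kg to 30 mg/kg, with a real chance that only a limit is reported again.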

Compound 4, dose for half-maximal effect: 0.5 mg/kg
Estimate against measurement, compound 4: 20-fold (1.30 log units) above; measured number below the stated range.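

In this assay, going by these compounds alone, hydrogen in place of chloro on the aromatic carbon ortho to a large group is an at least 8.0-fold lower number from compound 1 to compound 4 (0.90 log units; beyond the scatter), the first step whose size can be read at all, though only as a minimum. The phenyl group also stands apart from the saturated groups on the chain carbon, with an at least 20-fold lower number from compound 3 to compound 4 (1.30 log units; beyond the scatter) and an at least 20-fold lower number from compound 2 to compound 4 (1.30 log units; beyond the scatter). Among the four compounds, only the benzyl group of compound 4 gives a number, while 2-chlorobenzyl, cyclopentyl and butyl leave limits, and the steps among those three cannot be read.

On these data alone, whether fluoro or methyl on that same aromatic carbon would be tolerated, or a longer chain between the phenyl and the ring nitrogen, remains open. Nothing measured here accounts for the effect of the chloro.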